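The source may hold more compounds than are shown below. What is called first, only, known or untested is meant among the compounds shown, and "the series" means these compounds.

Values measured so far in a functional assay on THP-1 cells (Homo sapiens) for cytotoxicity, read by MTT assay, with a stated time of 24 h (on this read-out higher numbers stand for weaker inhibition and lower numbers for stronger inhibition), are these
- compound 1 `COc1cc(/C=C2\CN(C)C/C(=C\c3ccc(F)cc3)C2=O)cc(OC)c1OC` gives 6130 nM
- compound 2 `COc1cc(/C=C2\CN(C)C/C(=C\c3ccc(Br)cc3)C2=O)cc(OC)c1OC` gives 5330 nM
- compound 3 `CN1C/C(=C\c2ccc(Cl)cc2)C(=O)/C(=C/c2cccc([N+](=O)[O-])c2)C1` gives 7870 nM

Compound 3 at 7870 nM lies within the scatter of both other compounds, so these numbers do not separate the three. Next comes compound 4 `CN1C/C(=C\c2cccc([N+](=O)[O-])c2)C(=O)/C(=C/c2ccc(Cl)cc2Cl)C1` which follows from compound 3 through the change chloro in place of hydrogen on an aromatic carbon that turns 4-chlorophenyl into 2,4-dichlorophenyl.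

For the measured compounds named here, only one measured step bears on this, and only loosely: a 1.2-fold lower number from compound 1 to compound 2 (0.06 log units; within the scatter) for bromo in place of fluoro on an aromatic carbon. Going by the values given here, that step exchanges one halogen for another, whereas here chloro replaces hydrogen, and no measured pair adds a halogen to an aromatic ring. No step beyond the scatter is therefore expected in this assay in either direction. The estimated move is a 1.2-fold lower number from compound 3 to compound 4 (0.08 log units; within the scatter) and it carries little weight. Compound 4 is expected at 6500 nM with an estimated range from 3000 nM to 13000 nM for the coming measurement.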

Compound 4, half-maximal inhibitory concentration: 3560 nM
For compound 4 the middle estimate is 1.8-fold (0.26 log units) above the measured one, and the stated range covers the measured number.
By their numbers in this assay, from the lowest: compounds 4, 2, 1 and 3 (each within the scatter of the next, the first and the last beyond it).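

In this assay the series shows its first step beyond the scatter: adding chloro to turn 4-chlorophenyl into 2,4-dichlorophenyl gives a 2.2-fold lower number from compound 3 to compound 4 (0.34 log units; beyond the scatter), a modest move. For the compounds shown here, the only earlier step, a 1.2-fold lower number from compound 1 to compound 2 (0.06 log units; within the scatter), exchanged one halogen for another and stayed within the scatter, so it gave no sign that a change on the aromatic ring could register at all. Here a new chloro on an aromatic carbon, ortho to a large group and meta to a chloro group, does register, and no measured evidence on hand accounts for the step.

This reading rests on a single pair. Going by these compounds, whether an amine or a carboxylic acid at the same place gives a step of like size stays open, as does whether the chloro addition holds with a different group on the other aromatic ring.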